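The source may report more compounds than this note shows. Statements on the series, on what has been measured and on what is new or still open speak of the compounds shown alone.

Compound 1 `CCCCCCOc1cc(OC)c(Br)cc1C(C)=O` and compound 2 `CCCCCCCCOc1cc(OC)c(Br)cc1C(C)=O` share one core; compound 3 `CCCCCCCCCCCCOc1cc(OC)ccc1C(C)=O` and compound 4 `CCCCCCCCCCCCCCOc1cc(OC)ccc1C(C)=O` share another, and the difference between the two cores is not broken down here. In a functional assay, with stated times of 30 s and 6 min, in the presence of a further agent that is not named here (a higher number here means a weaker inhibitor, a lower number a stronger inhibitor), compound 1 gives 34000000 nM, compound 2 gives 30900000 nM and compound 3 gives 28500000 nM, all three values lying within the scatter of one another. The change from compound 1 to compound 2 is ethyl in place of hydrogen on a saturated chain carbon, six bonds along the chain from an oxygen on an aromatic ring and moved this assay by a 1.1-fold lower number from compound 1 to compound 2 (0.04 log units; within the scatter). The change from compound 3 to compound 4 is ethyl in place of hydrogen on a saturated chain carbon, ten or more bonds along the chain from an oxygen on an aromatic ring. It is the same kind of change, but the place along the chain differs, as the two descriptions of the change show. The expectation for compound 4 rests on a 1.1-fold lower number from compound 1 to compound 2 (0.04 log units; within the scatter) lying within the scatter. A step of a 1.1-fold lower number from compound 3 to compound 4 (0.02 log units; within the scatter) is therefore expected. Compound 4 is estimated at 27000000 nM in this assay, between 14000000 nM and 52000000 nM.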

Compound 4, half-maximal inhibitory concentration: 35900000 nM
Estimate against measurement, compound 4: 1.3-fold (0.12 log units) below; the range from low to high includes it.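

In this assay, ethyl in place of hydrogen gives a 1.3-fold higher number from compound 3 to compound 4 (0.10 log units; within the scatter), and the step does not differ from the earlier one on the other core: the same change on two cores in this assay, a 1.1-fold lower number (0.04 log units; within the scatter) from compound 1 to compound 2 and a 1.3-fold higher number (0.10 log units; within the scatter) from compound 3 to compound 4, 1.4-fold (0.14 log units) apart, within the scatter of two such steps

On these two pairs, the change carries from one core to the other without a difference that can be told apart. This does not show that the two cores would respond alike to a change with a step beyond the scatter, and the place along the chain is not the same in the two steps.

The compounds shown leave open whether an amine or a carboxylic acid at the end of the chain would move this assay beyond the scatter. They also leave open how a much shorter chain would behave on either core.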